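This account rests on a few compounds, and the source may have more. Where it says the series, first, only, none or still open, it means among the compounds named here.

Among the measured compounds shown here, compound 1 `CCOC(=O)c1ccc(/N=N/N(C)C(=O)[C@H](C)NC(C)=O)cc1` is one of three compounds measured in a physicochemical assay for metabolic stability, read by HPLC, in phosphate buffer, at pH 7.7; a higher number here means that the compound lasts longer, a lower number that the compound disappears faster; compound 1 gives 15.7 h, the second highest number of the three. Compound 2 `CC(=O)N[C@@H](C)C(=O)N(C)/N=N/c1ccc(C)cc1` gives 46.5 h and compound 3 `CC(=O)NCC(=O)N(C)/N=N/c1ccc(C#N)cc1` gives 7.6 h in this assay. Compound 4 `CC(=O)N[C@@H](C)C(=O)N(C)/N=N/c1ccc(C#N)cc1` differs from compound 1 by cyano in place of ethoxycarbonyl on an aromatic carbon. For the measured compounds named here, the one measured step at the same position is a 3.0-fold higher number from compound 1 to compound 2 (0.47 log units; beyond the scatter), which replaced the ethoxycarbonyl with a different group than a cyano, so it does not settle the direction here. Compound 3 carries a cyano but also differs elsewhere, so its number only hints at a lower value. Compound 4 is therefore expected to sit somewhat below compound 1, with a 1.6-fold lower number from compound 1 to compound 4 (0.20 log units; within the scatter), giving an estimate of 10 h with a range from 5 h to 22 h.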

Compound 4, half-life: 9.8 h
Compound 4: middle estimate off by 1.0-fold (0.01 log units), on the high side, and the stated range covers the measured number.
By their numbers in this assay, from the lowest: compounds 3, 4 and 1 (each within the scatter of the next, the first and the last beyond it); then compound 2.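

In this assay, cyano and ethoxycarbonyl on the aromatic carbon cannot be told apart, with a 1.6-fold lower number from compound 1 to compound 4 (0.20 log units; within the scatter). Methyl at the same place now stands beyond the scatter of both groups, and the step against cyano is the largest here, with a 4.7-fold lower number from compound 2 to compound 4 (0.68 log units; beyond the scatter). The other single change, methyl in place of hydrogen on the saturated chain carbon, stays within the scatter, with a 1.3-fold higher number from compound 3 to compound 4 (0.11 log units; within the scatter).

Nothing measured here explains these numbers. Open, on these data alone, is whether an amine, a carboxylic acid or a longer chain on the aromatic carbon would group with methyl or with cyano and ethoxycarbonyl.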